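The compounds below may be only part of what the source reports. "The series", "measured", "known", "first", "only" and "open" are said of these compounds alone.

Measured in a functional assay on MGC-803 cells (Homo sapiens) for inhibition, read by sulforhodamine B assay; a lower number here means a stronger inhibitor, a higher number a weaker inhibitor:
- compound 1 `O=C1C(Nc2ccccc2F)=CC(=O)c2c1nc1n2[C@H]2OC[C@@H](O)[C@H]2OC1`: 2000 nM
- compound 2 `COc1ccccc1NC1=CC(=O)c2c(nc3n2[C@H]2OC[C@@H](O)[C@H]2OC3)C1=O`: 1670 nM

Compound 2, at 1670 nM, cannot be ordered against compound 1 on these two numbers. Within the data shown here, the only measured step is a 1.2-fold lower number from compound 1 to compound 2 (0.08 log units; within the scatter).

Next comes compound 3 `CCOc1ccc(NC2=CC(=O)c3c(nc4n3[C@H]3OC[C@@H](O)[C@H]3OC4)C2=O)cc1`, with this change from compound 2: 4-ethoxyphenyl in place of 2-methoxyphenyl on an amine nitrogen. That single measured step bears on the change only loosely. Among the measured compounds shown here, it also alters the aromatic group on the amine nitrogen, but no measured compound carries a 4-ethoxyphenyl. With so little evidence, no shift beyond the scatter is expected in this assay, and no direction can be favoured. The estimated step is a 1.0-fold lower number from compound 2 to compound 3 (0.02 log units; within the scatter). The expected value for compound 3 is 1600 nM, with an estimated range of 550 nM to 4500 nM.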

Compound 3, half-maximal inhibitory concentration: 2090 nM
Estimate against measurement, compound 3: 1.3-fold (0.12 log units) below; low and high end bracket the measured number.
By their numbers in this assay, from the lowest: compounds 2, 1 and 3 (each within the scatter of the next).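

In this assay, placing a 4-ethoxyphenyl on the amine nitrogen gives a 1.3-fold higher number from compound 2 to compound 3 (0.10 log units; within the scatter), and the same group in place of 2-fluorophenyl gives a 1.0-fold higher number from compound 1 to compound 3 (0.02 log units; within the scatter). Until now the series held only the 2-fluorophenyl and 2-methoxyphenyl groups; with the 4-ethoxyphenyl added, all three aromatic groups at this position stay within the scatter of one another, and no compound shown goes against that. No supporting data are available to account for this result.

The compounds shown leave open whether any group on this nitrogen can shift the number beyond the scatter, for instance a carboxylic acid on the phenyl ring or a saturated cyclohexyl in place of the phenyl. They also leave open whether changes to the shared core would matter more than changes at this position.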